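A Dichlorophenyl Variant of a Nucleoside Transporter Inhibitor

This account rests on a few compounds, and the source may have more. Where it says the series, first, only, none or still open, it means among the compounds named here.

Measured compounds:
compound 1, `N#Cc1ccccc1CSc1ncnc2c1ncn2[C@@H]1O[C@H](CO)[C@@H](O)[C@H]1O`: 38.9 nM
compound 2, `Cc1cccc(CSc2ncnc3c2ncn3[C@@H]2O[C@H](CO)[C@@H](O)[C@H]2O)c1`: 16.2 nM
compound 3, `CC(C)(C)c1ccc(CSc2ncnc3c2ncn3[C@@H]2O[C@H](CO)[C@@H](O)[C@H]2O)cc1`: 10000 nM

All three share one core and were tested in an assay on isolated protein for inhibition of Equilibrative nucleoside transporter 1 (Homo sapiens); on this read-out higher numbers stand for weaker inhibition and lower numbers for stronger inhibition. Compound 1 stands second highest of the three numbers: compound 2 lies a little lower, a 2.4-fold lower number from compound 1 to compound 2 (0.38 log units; beyond the scatter), while compound 3 lies far higher, a 260-fold higher number from compound 1 to compound 3 (2.41 log units; beyond the scatter). Compound 4, `OC[C@H]1O[C@@H](n2cnc3c(SCc4ccc(Cl)cc4Cl)ncnc32)[C@H](O)[C@@H]1O`, is not yet measured. It differs from compound 1 in one place: 2,4-dichlorophenyl in place of 2-cyanophenyl on a saturated chain carbon bound to a sulfur.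

Going by the values given here, two steps bear on this. Exchanging the group on this saturated chain carbon for 3-methylphenyl moved the number modestly, as seen from compound 1 to compound 2, whereas 4-(tert-butyl)phenyl produced a large loss, seen from compound 2 to compound 3, a 620-fold higher number from compound 2 to compound 3 (2.79 log units; beyond the scatter). A 2,4-dichlorophenyl group is not directly comparable to either, so the step from compound 1 to compound 4 is expected to be small, a 1.3-fold higher number from compound 1 to compound 4 (0.11 log units; within the scatter), with wide uncertainty. Compound 4 is therefore estimated at 50 nM, within 12 nM to 300 nM.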

Compound 4, inhibition constant: 4.37 nM
Compound 4: the middle estimate sits 11-fold (1.06 log units) above what was measured; the measured number lies below the stated range.
By their numbers in this assay, from the lowest: compound 4; then compound 2; then compound 1; then compound 3.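

In this assay a 2,4-dichlorophenyl group on a saturated chain carbon bound to a sulfur gives the lowest number of the four compounds, with an 8.9-fold lower number from compound 1 to compound 4 (0.95 log units; beyond the scatter) and a 3.7-fold lower number from compound 2 to compound 4 (0.57 log units; beyond the scatter) as its two modest gains. Going by these compounds alone, this place can therefore still improve on 3-methylphenyl, the best group among the earlier compounds. The much larger change, a 2300-fold lower number from compound 3 to compound 4 (3.36 log units; beyond the scatter) in this same place, shows that the heavy loss belongs to 4-(tert-butyl)phenyl and not to every substituted phenyl ring here.

Nothing presented here explains why the two chlorine atoms give this result. As far as these compounds go, it also remains open whether one chlorine would do as well, and how an unsubstituted phenyl or a phenyl carrying two bromine atoms would compare.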